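This account rests on a few compounds, and the source may have more. Where it says the series, first, only, none or still open, it means among the compounds named here.

Compounds measured so far, in a functional assay on CHO cells with adenosine receptor A1 (Homo sapiens) as the target, read by cAMP accumulation and immunoassay, with a stated time of 6 min, tested at 0.1 uM; on this read-out lower numbers stand for a stronger effect and higher numbers for a weaker effect at the one concentration tested:

Compound 1 `Nc1scc(CN2CCN(c3cccc(C(F)(F)F)c3)CC2)c1C(=O)c1ccc(Cl)cc1` gives -30%.
Compound 2 `Nc1scc(CN2CCN(c3ccc(Cl)c(C(F)(F)F)c3)CC2)c1C(=O)c1ccc(Cl)cc1` gives -12%.
Compound 3 `Nc1scc(CN2CCN(c3cccc4ccccc34)CC2)c1C(=O)c1ccc(Cl)cc1` gives 0%.

Compound 3 stands highest of the three numbers. Its nearest neighbour is compound 2, a number 12 percentage points higher from compound 2 to compound 3 (beyond the scatter), and its furthest is compound 1, a number 30 percentage points higher from compound 1 to compound 3 (beyond the scatter). The step of a number 18 percentage points higher from compound 1 to compound 2 (beyond the scatter) concerns a chloro in place of hydrogen on an aromatic carbon and does not touch the group changed here.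

The unmeasured compound 4 `Nc1scc(CN2CCN(c3cccc(F)c3)CC2)c1C(=O)c1ccc(Cl)cc1` differs from compound 3 in one place: 3-fluorophenyl in place of naphthalen-1-yl on an amine nitrogen in a ring. The two steps that bear on it are those into compound 3, in which naphthalen-1-yl entered in place of a substituted phenyl on the ring nitrogen and the number moved upward each time. Compound 4 goes the other way, and its 3-fluorophenyl is closest among the measured groups to the 3-(trifluoromethyl)phenyl of compound 1. Among the compounds with values here, no measured step shows fluoro in place of trifluoromethyl, so the exact size is uncertain. A downward step beyond the scatter is therefore expected, a number 20 percentage points lower from compound 3 to compound 4 (beyond the scatter). Compound 4 is estimated at -20%, with a range from -40% to 0%.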

Compound 4, a percentage reported as activity, at one concentration (the size of the read-out at that concentration, not a potency): -37%
Compound 4: middle estimate off by 17 percentage points, on the high side, within the range that was stated.
By their numbers in this assay, from the lowest: compounds 4 and 1 (each within the scatter of the next); then compound 2; then compound 3.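

At the amine nitrogen in a ring, 3-fluorophenyl in place of naphthalen-1-yl gives a large step in this assay, a number 37 percentage points lower from compound 3 to compound 4 (beyond the scatter), and its replacement of 4-chloro-3-(trifluoromethyl)phenyl also gives a step beyond the scatter, a number 25 percentage points lower from compound 2 to compound 4 (beyond the scatter). The new result adds a direct comparison of fluoro and trifluoromethyl on an aromatic carbon, a number 7 percentage points lower from compound 1 to compound 4 (within the scatter), so this assay does not separate these two substituents in this pair, while compound 2 and compound 3 each stand apart from compound 4. Nothing available offers an explanation for these differences.

From the compounds shown here alone, how a plain phenyl, a 3-chlorophenyl or a 3-methoxyphenyl on that same nitrogen would read remains open, and so does whether a benzyl or cyclohexyl group there would read like compound 4 or like compound 3. Also open, going by these compounds, is whether the near match between the fluoro and trifluoromethyl compounds would hold at other concentrations, as this read-out reports the size of the effect at one concentration and not a potency.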